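Replacing the pyrazolyl ring on the core of compound 2

This account rests on a few compounds, and the source may have more. Where it says the series, first, only, none or still open, it means among the compounds named here.

Compound 2 `CS(=O)(=O)c1cc(C(=O)N=C(N)N)ccc1-n1cccn1` is the weakest of the three measured compounds in a functional assay for inhibition of sodium/hydrogen exchanger (Oryctolagus cuniculus) (a higher number here means a weaker inhibitor, a lower number a stronger inhibitor), where compound 2 gives 160 nM. Compound 1 `Cc1cc(OCc2ccccc2)c(S(C)(=O)=O)cc1C(=O)N=C(N)N` gives 28 nM and compound 3 `Cc1cc(-n2cccn2)c(S(C)(=O)=O)cc1C(=O)N=C(N)N` gives 25 nM. The step of a 6.4-fold lower number from compound 2 to compound 3 (0.81 log units; beyond the scatter) and the step of a 1.1-fold lower number from compound 1 to compound 3 (0.05 log units; within the scatter) frame what is known: adding the methyl moves the number beyond the scatter, while exchanging the group on the ring carbon bearing the pyrazolyl does not.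

Compound 4 `CS(=O)(=O)c1cc(C(=O)N=C(N)N)ccc1-n1ccc(=O)cc1` differs from compound 2 only at that ring carbon: a group of 7 heavy atoms (5 carbon, 1 nitrogen, 1 oxygen; one six-membered aromatic ring with 1 hetero atom) in place of a group of 5 heavy atoms (3 carbon, 2 nitrogen; one five-membered aromatic ring with 2 hetero atoms), on an aromatic carbon

Among the measured compounds shown here, the only step that bears on this position is a 1.1-fold lower number from compound 1 to compound 3 (0.05 log units; within the scatter), which shows the pyrazolyl and the benzyloxy group interchangeable within the scatter, but in the methyl-bearing series. For the measured compounds named here, no measured pair involves the entering six-membered ring, so its effect is unknown. The nearest comparison suggests a change at this carbon may be tolerated, and the expectation for compound 4 is therefore a step of a 1.1-fold lower number from compound 2 to compound 4 (0.03 log units; within the scatter) not beyond the scatter. Compound 4 is estimated at 150 nM in this assay, with a range from 50 nM to 500 nM.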

Compound 4, half-maximal inhibitory concentration: 710 nM
For compound 4 the middle estimate is 4.7-fold (0.68 log units) below the measured one; measured number above the stated range.
By their numbers in this assay, from the lowest: compounds 3 and 1 (each within the scatter of the next); then compound 2; then compound 4.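

At this carbon, ortho to a methylsulfonyl group, the group is not freely exchangeable: in this assay, the six-membered aromatic ring with 1 hetero atom in place of 1H-pyrazol-1-yl gives a 4.4-fold higher number from compound 2 to compound 4 (0.65 log units; beyond the scatter) (modest). The earlier pair at this carbon, a 1.1-fold lower number from compound 1 to compound 3 (0.05 log units; within the scatter), came from the methyl-bearing series, and its result does not extend to this exchange on the core of compound 2. The counts of hydrogen-bond donors and acceptors and the net charge are the same for the leaving and entering groups, so these counts do not separate compound 2 from compound 4, and no measurement available here accounts for the difference.

On these data alone, whether the same ring exchange gives a step of similar size on the methyl-bearing core of compound 3 remains open. Also open, as far as these compounds go, is whether the step follows ring size or the oxygen of the entering group, and where an amine or a carboxylic acid at this carbon would fall relative to compound 2 and compound 4.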